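This account rests on a few compounds, and the source may have more. Where it says the series, first, only, none or still open, it means among the compounds named here.

In a functional assay on the whole organism (brain) with Mus musculus as the target (a higher number here means that more compound is needed for the effect, a lower number that less compound is needed), compound 1 (`O=[N+]([O-])c1cccc(OCCc2c[nH]cn2)c1`) gives 0.9 mg/kg and compound 2 (`N#Cc1cccc(OCCc2c[nH]cn2)c1`) gives 2.9 mg/kg. With cyano in place of nitro on an aromatic carbon, the numbers show a 3.2-fold higher number from compound 1 to compound 2 (0.51 log units; beyond the scatter). Compound 3 (`COC(=O)c1ccc(OCCc2c[nH]cn2)cc1`) gives > 3 mg/kg in this assay. This is a limit of the assay and not a number, so compound 3 has no exact position on the scale.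

Compound 4 (`CCC(=O)c1ccc(OCCc2c[nH]cn2)cc1`) carries ethyl in place of methoxy on a carbonyl carbon, which also reads as methoxycarbonyl to propanoyl: ethyl in place of methoxy on a carbonyl carbon. Among the compounds with values here, no measured step covers this change. The only one available, a 3.2-fold higher number from compound 1 to compound 2 (0.51 log units; beyond the scatter), exchanges different groups and offers a modest size as a rough guide, but no direction for this change. No step beyond the scatter is therefore expected in this assay, and neither direction is favoured. The expected step is a number no higher from compound 3 to compound 4 (the limit leaves the size open). Compound 4 is estimated at 3 mg/kg, with an expected range from 1 mg/kg to 9 mg/kg.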

Compound 4, dose for half-maximal effect: 0.95 mg/kg
Compound 4: middle estimate off by 3.2-fold (0.50 log units), on the high side, and the stated range ends above it.
By their numbers in this assay, from the lowest: compounds 1 and 4 (each within the scatter of the next); then compound 2. At a limit, above all of these: compound 3.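

In this assay the exchange of methoxy for ethyl on a carbonyl carbon gives an at least 3.1-fold lower number from compound 3 to compound 4 (0.49 log units; beyond the scatter), so the group on this carbonyl carbon clearly affects the dose needed. Within the data shown here, the one earlier step, cyano in place of nitro on an aromatic carbon, said nothing about this carbonyl carbon or about this pair of groups. Compound 3 stands at a limit and not at a number, so the full size of the step stays open: the limit of > 3 mg/kg in this assay, at which 1 of the 4 values shown sits.

On these data alone, whether a longer chain, an amine or a hydroxyl group in place of ethyl on the same carbonyl carbon would keep the number of compound 4 remains open. The compounds shown also cannot separate the loss of methoxy from the arrival of ethyl, and they give no cause for the step.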